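The compounds below may be only part of what the source reports. "The series", "measured", "known", "first", "only" and "open" are said of these compounds alone.

Of the compounds shown here, three sharing one core have been measured. Compound 1 `CCCCCOc1ccc2oc(/C=C/[S+](C)[O-])cc(=O)c2c1` carries a pentyl group on an oxygen on the aromatic ring; in a functional assay on DLD-1 cells (Homo sapiens) for cytotoxicity, with a stated time of 48 h (on this read-out higher numbers stand for weaker inhibition and lower numbers for stronger inhibition), compound 1 gives 6600 nM. Compound 2 `CCCC(=O)Oc1ccc2oc(/C=C/[S+](C)[O-])cc(=O)c2c1` bears a propylcarbonyl group in place of that pentyl, and compound 2 gives 8700 nM. Compound 3 `Cc1cccc2c(=O)cc(/C=C/[S+](C)[O-])oc12` has a methyl on its core and gives 6800 nM. Compound 2 shows the highest of the three numbers, yet its separation from compound 3 and from compound 1 stays within the scatter, so no order among the three can be drawn. Within the data shown here, the only single-site step so far, a 1.3-fold higher number from compound 1 to compound 2 (0.12 log units; within the scatter), is likewise within the scatter.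

Compound 4 `C[S+]([O-])/C=C/c1cc(=O)c2cc(O)ccc2o1` is not yet measured. It differs from compound 2 in this way: hydrogen in place of propylcarbonyl on an oxygen on an aromatic ring. Among the measured compounds shown here, the one step that bears on this site, from compound 1 to compound 2, showed that exchanging pentyl for propylcarbonyl on that oxygen left the number within the scatter. From the compounds shown here alone, whether stripping the oxygen down to a hydroxy behaves the same is untested. On that thin basis compound 4 is expected to give 8000 nM, with a likely range from 2500 nM to 25000 nM. The step from compound 2 that this estimate implies, a 1.1-fold lower number from compound 2 to compound 4 (0.04 log units; within the scatter), is expected to remain within the scatter, though the wide range reflects that this change is not covered by any measured step.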

Compound 4, half-maximal inhibitory concentration: > 10000 nM
Compound 4: a limit, no number (the forecaster's own chance of this, stated with the estimate: 10%); middle value at least 1.2-fold (0.09 log units) from the limit.
By their numbers in this assay, from the lowest: compounds 1, 3 and 2 (each within the scatter of the next). At a limit, above all of these: compound 4.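

In this assay compound 4 gives > 10000 nM, which is a limit of the assay and not a number. On the oxygen on the aromatic ring, hydrogen in place of propylcarbonyl gives an at least 1.1-fold higher number from compound 2 to compound 4 (0.06 log units; that floor lies within the scatter), and hydrogen in place of pentyl gives an at least 1.5-fold higher number from compound 1 to compound 4 (0.18 log units; that floor lies within the scatter). Until now this position had shown only an exchange of one group for another on the oxygen, whereas the hydroxy of compound 4 is the first case here that reaches the limit of the assay instead of giving a number, though both floors lie within the scatter and so establish only that the change may be small or may be larger.

The compounds shown leave open how far the true value of compound 4 lies beyond its limit, and so whether the hydroxy differs from the pentyl and propylcarbonyl groups by more than the scatter. They also leave open whether other groups on this oxygen, such as a longer chain, an amine or a carboxylic acid, would move the number beyond the scatter.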